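Halogen swap on two salicylanilide-type cores

This account rests on a few compounds, and the source may have more. Where it says the series, first, only, none or still open, it means among the compounds named here.

Compound 1 `O=C(Nc1ccc(C(F)(F)F)cc1)c1cc(Cl)ccc1O` and compound 2 `O=C(Nc1ccc(C(F)(F)F)cc1)c1cc(Br)ccc1O` share one core; compound 3 `O=C(NCCCCl)Oc1ccc(Cl)cc1C(=O)Nc1ccc(C(=O)c2ccccc2)cc1` carries a different core, and the difference between the two cores is not broken down here. Compound 4 `O=C(NCCCCl)Oc1ccc(Br)cc1C(=O)Nc1ccc(C(=O)c2ccccc2)cc1` is not yet measured.

In an ADME assay on MONO-MAC-6 cells (Homo sapiens) for cytotoxicity, read by MTT assay, with a stated time of 16 h (on this read-out lower numbers stand for stronger inhibition and higher numbers for weaker inhibition), compound 1 gives 5300 nM, compound 2 gives 7600 nM and compound 3 gives 16100 nM. Among the compounds with values here, the only measured step in the set is a 1.4-fold higher number from compound 1 to compound 2 (0.16 log units; within the scatter), made by bromo in place of chloro on an aromatic carbon. The change from compound 3 to compound 4 is bromo in place of chloro on an aromatic carbon, the same kind of change rather than the same one: on the core of compound 1 the position is para to a hydroxy group (1 heavy atom), on the core of compound 3 it is para to a ((3-chloropropyl)carbamoyl)oxy group (8 heavy atoms).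

Resting on the single comparable step, compound 4 is expected to show a 1.2-fold higher number from compound 3 to compound 4 (0.09 log units; within the scatter), because the same kind of swap gave a 1.4-fold higher number from compound 1 to compound 2 (0.16 log units; within the scatter). Compound 4 is therefore estimated at 20000 nM, with a range from 10000 nM to 40000 nM in this assay.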

Compound 4, half-maximal inhibitory concentration: 12600 nM
Beside the measured number, compound 4's estimate is 1.6-fold (0.20 log units) above it; the range from low to high includes it.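

In this assay, bromo in place of chloro on the core of compound 3 gives a 1.3-fold lower number from compound 3 to compound 4 (0.11 log units; within the scatter). Set beside the earlier step on the other core, the two results do not differ beyond what repeated measurements would produce: the same change on two cores in this assay, a 1.4-fold higher number (0.16 log units; within the scatter) from compound 1 to compound 2 and a 1.3-fold lower number (0.11 log units; within the scatter) from compound 3 to compound 4, 1.8-fold (0.26 log units) apart, within the scatter of two such steps In this series and this assay, the swap therefore carries across the two cores as a change within the scatter on both, and the opposite directions of the two steps are no sign of a core-dependent effect, although two pairs cannot show that the swap would behave the same way on any further core or in any other assay.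

Still open, on these data alone, is whether a fluoro, an iodo or a nitrile on the same aromatic carbon would move the number beyond the scatter on either core. Also open, as far as these compounds go, is what an amine or a longer chain in place of the 3-chloropropyl chain would do on the core of compound 3.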